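A Nitrile Gives Way to Ethylsulfonyl

A few compounds are considered here, and "the series" means these few. Any claim that something is new, unique, unknown or untested is made for them only; others in the source may bear on it.

Compound 1 `Cc1ccc2ccc(-c3cccc(O)c3)cc2n1` and compound 2 `Cc1ccc2ccc(-c3cc(C#N)cc(C#N)c3)cc2n1` share a core and differ only in the attached aryl ring. In a functional assay on CHO cells for inhibition of metabotropic glutamate receptor 5 (Rattus norvegicus), read by FLIPR and calcium flux (a lower number here means a stronger inhibitor, a higher number a weaker inhibitor), compound 1 gives 19000 nM, while compound 2 gives 2 nM, the lower of the two numbers and far beyond the scatter from compound 1. Compound 3 `CCS(=O)(=O)c1cc(C#N)cc(-c2ccc3ccc(C)nc3c2)c1` follows from compound 2 by ethylsulfonyl in place of cyano on an aromatic carbon. For the measured compounds named here, no measured step of this kind is at hand. A modest move toward a higher number, a 5.0-fold higher number from compound 2 to compound 3 (0.70 log units; beyond the scatter), is expected in this assay. Compound 3 is therefore estimated at 10 nM, with a range from 2 nM to 60 nM.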

Compound 3, half-maximal inhibitory concentration: 1090 nM
Compound 3: the middle estimate sits 110-fold (2.04 log units) below what was measured; measured number outside the range, above it.
By their numbers in this assay, from the lowest: compound 2; then compound 3; then compound 1.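

In this assay, ethylsulfonyl in place of cyano on this aromatic carbon brings a 550-fold higher number from compound 2 to compound 3 (2.74 log units; beyond the scatter). The position is therefore far from indifferent to this change: with the other cyano group left in place, this one exchange is enough for a large loss of inhibition. Nothing at hand gives a reason for the size of this step. As far as these compounds go, what remains open is how a methylsulfonyl, a methoxy group or an amine would fare on the same carbon, and so whether the ethyl chain, the sulfonyl or the loss of the cyano group sets the outcome.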